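A few compounds are considered here, and "the series" means these few. Any claim that something is new, unique, unknown or untested is made for them only; others in the source may bear on it.

In a functional assay (Homo sapiens) (on this read-out higher numbers stand for weaker inhibition and lower numbers for stronger inhibition), three compounds have been measured so far. Compound 1 (`Nc1nc2ccnc(-c3cccc(C(F)(F)F)c3)n2n1`) gives 2200 nM; 2200 nM (2 entries), and compound 2 (`Cc1cccc(-c2nccc3nc(N)nn23)c1`) gives 5500 nM. Compound 3 (`CC(=O)Nc1nc2ccnc(-c3cccc(NS(=O)(=O)c4ccc(C)cc4)c3)n2n1`) gives 1600 nM. Among the measured compounds shown here, that number is clearly lower than the one for compound 2, beyond the usual scatter, but it lies within the scatter of the one for compound 1. Compound 4 (`CC(=O)Nc1nc2c(C)cnc(-c3cccc(NS(=O)(=O)c4ccc(C)cc4)c3)n2n1`) has methyl in place of hydrogen on an aromatic carbon. For the measured compounds named here, no measured pair shows what this change does, so no step beyond the scatter is expected in this assay. The expected move is small: a 1.2-fold lower number from compound 3 to compound 4 (0.09 log units; within the scatter). Compound 4 is estimated at 1300 nM, with an expected range of 400 nM to 4000 nM.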

Compound 4, half-maximal inhibitory concentration: 51800 nM
For compound 4 the middle estimate is 40-fold (1.60 log units) below the measured one; the measured number lies above the stated range.
By their numbers in this assay, from the lowest: compound 3; then compound 2; then compound 4.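

In this assay, placing one methyl on an aromatic carbon of the six-membered aromatic ring with 2 nitrogen gives a 32-fold higher number from compound 3 to compound 4 (1.51 log units; beyond the scatter), a large loss of inhibition. This shows that this ring position is sensitive: adding a single carbon atom here is enough to weaken inhibition sharply. No available measurement explains this loss. As far as these compounds go, whether fluorine, a hydroxyl group or a longer chain at this carbon would act the same way remains open. So does whether the methyl would have this effect on compound 1 or compound 2.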